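Swapping a Ring Substituent on a Pyrazoline Scaffold

This account rests on a few compounds, and the source may have more. Where it says the series, first, only, none or still open, it means among the compounds named here.

Measured so far:
compound 1 `Clc1cccc(C2CC(c3ccc4c(c3)OCCO4)=NN2c2ccccc2)c1` gives 1750 nM
compound 2 `Oc1ccccc1C1CC(c2ccc(Cl)c(Cl)c2)=NN1c1ccccc1` gives 1570 nM

In a functional assay on WM 266-4 cells (Homo sapiens) for antiproliferative activity, read by MTT assay, with a stated time of 24 h (on this read-out lower numbers stand for stronger inhibition of growth and higher numbers for weaker inhibition of growth), compound 1 gives 1750 nM, and compound 2 gives 1570 nM, a number that sits within the usual scatter of compound 1's, so the two cannot be told apart. Compound 3 `Cc1ccc(C2CC(c3ccc4c(c3)OCCO4)=NN2c2ccccc2)cc1` is not yet measured. It differs from compound 1 in one place: 4-methylphenyl in place of 3-chlorophenyl on a saturated ring carbon. For the measured compounds named here, no measured pair shows the effect of this change, so the expected step of a 1.1-fold higher number from compound 1 to compound 3 (0.06 log units; within the scatter) is taken as none beyond the scatter. Compound 3 is therefore estimated at 2000 nM, with a range from 900 nM to 5000 nM.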

Compound 3, concentration for 50% growth inhibition: 2530 nM
For compound 3 the middle estimate is 1.3-fold (0.10 log units) below the measured one; measured number inside the range.
By their numbers in this assay, from the lowest: compounds 2, 1 and 3 (each within the scatter of the next).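

For the compounds shown here, the first pair that differs in one place, read in this assay, shows a 1.4-fold higher number from compound 1 to compound 3 (0.16 log units; within the scatter) when 4-methylphenyl replaces 3-chlorophenyl on a saturated ring carbon. At this position, then, these two substituted phenyl groups cannot be told apart in growth inhibition. Nothing available here offers an explanation for this result. Still open, on these data alone, is how this position would respond to a very different group, such as a phenyl ring carrying an amine or a carboxylic acid, or a longer chain in place of the ring.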